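A few compounds are considered here, and "the series" means these few. Any claim that something is new, unique, unknown or untested is made for them only; others in the source may bear on it.

Measured in a functional assay on U-937 cells (Homo sapiens) for antiproliferative activity, read by MTT assay, with a stated time of 24 h; on this read-out lower numbers stand for stronger inhibition and higher numbers for weaker inhibition:
- compound 1 `CCCCc1oc2ccccc2c1C(=O)c1ccc(OCC(=O)Nc2ccccc2)cc1`: 25900 nM
- compound 2 `CCCCc1oc2ccccc2c1C(=O)c1ccc(OCC(=O)N[C@@H](C)c2ccccc2)cc1`: 33800 nM

Among the compounds with values here, compound 2, at 33800 nM, sits level with compound 1 at 25900 nM, the only other measured compound. The gap between them is a 1.3-fold higher number from compound 1 to compound 2 (0.12 log units; within the scatter).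

Compound 3 `CCCCc1oc2ccccc2c1C(=O)c1ccc(OCCCC(=O)N2CCCC2)cc1` changes compound 2 as follows: 2-((pyrrolidin-1-yl)carbonyl)ethyl in place of (1-phenylethyl)carbamoyl on a saturated chain carbon bound to an oxygen on an aromatic ring. Here 2-((pyrrolidin-1-yl)carbonyl)ethyl stands in place of (1-phenylethyl)carbamoyl.

Within the data shown here, only one measured step bears on this, and only in part: a 1.3-fold higher number from compound 1 to compound 2 (0.12 log units; within the scatter), a swap of the group on the amide-type nitrogen. Among the measured compounds shown here, no measured step covers the replacement of the whole (1-phenylethyl)carbamoyl group, so the range must stay wide. With that single small step as a guide, no shift beyond the scatter is expected in this assay.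

For compound 3 the estimated value is 30000 nM, with an expected range of 12000 nM to 75000 nM.

This estimate means an expected 1.1-fold lower number from compound 2 to compound 3 (0.05 log units; within the scatter).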

Compound 3, half-maximal inhibitory concentration: 7500 nM
The estimate for compound 3 lay 4.0-fold (0.60 log units) above the measured number, outside the stated range (below it).
By their numbers in this assay, from the lowest: compound 3; then compounds 1 and 2 (each within the scatter of the next).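

In this assay, the replacement on the saturated chain carbon bound to an oxygen on an aromatic ring moves the number clearly, with a 4.5-fold lower number from compound 2 to compound 3 (0.65 log units; beyond the scatter) and a 3.5-fold lower number from compound 1 to compound 3 (0.54 log units; beyond the scatter), whereas the earlier swap on the amide-type nitrogen gave only a 1.3-fold higher number from compound 1 to compound 2 (0.12 log units; within the scatter). The change that matters here therefore goes beyond exchanging phenyl for 1-phenylethyl: the entering 2-((pyrrolidin-1-yl)carbonyl)ethyl group has a five-membered non-aromatic ring in place of the six-membered aromatic ring and no hydrogen-bond donor, and compound 3 gives the lowest number of the series. Nothing available accounts for this gain.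

Within the data shown here, the single replacement changes the chain and the amide part together, so their separate contributions remain unresolved. A phenylcarbamoyl group on the longer chain of compound 3, a (pyrrolidin-1-yl)carbonyl group directly on the saturated chain carbon, or a piperidine amide would help to separate them.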